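Methyl branching on the chain carbon: a small series

The source may hold more compounds than are shown below. What is called first, only, known or untested is meant among the compounds shown, and "the series" means these compounds.

Compound 1 `CCCOC(=O)C1=C(C)NC(=S)NC1c1ccsc1` gives 1% in an assay on membranes from HeLa cells for displacement of a labelled ligand from adenosine receptor A3 (Homo sapiens), read by scintillation counting, with a stated time of 180 min, tested at 1 uM; a lower number here means less inhibition, a higher number more inhibition at the concentration tested (going by the name of the read-out). Compound 2 `CC1=C(C(=O)OCC(C)C)C(c2ccsc2)NC(=S)N1` carries methyl in place of hydrogen on a saturated chain carbon bound to two saturated chain carbons and gives 2% in this assay, so the step of a number 1 percentage points higher from compound 1 to compound 2 (within the scatter) leaves the read-out essentially flat. Compound 3 `CCCC(=O)C1=C(C)NC(=O)NC1c1cccs1` gives 2% in this assay; the difference between the core of compound 3 and the core of compound 1 is not broken down here. Compound 4 `CC1=C(C(=O)CC(C)C)C(c2cccs2)NC(=O)N1` is not yet measured and differs from compound 3 by methyl in place of hydrogen on a saturated chain carbon bound to two saturated chain carbons, the same change that separates compound 1 from compound 2 at the same kind of place. Because a number 1 percentage points higher from compound 1 to compound 2 (within the scatter) stayed within the scatter, compound 4 is expected to show a step of no change at the digits printed from compound 3 to compound 4 (within the scatter) in this assay. Compound 4 is estimated at 2% in this assay, expected to lie between -5% and 9%.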

Compound 4, a percentage reported as inhibition, at one concentration (the size of the read-out at that concentration, not a potency): 18%
Estimate against measurement, compound 4: 16 percentage points below, outside the stated range (above it).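

The step does not carry over at a fixed size from one core to the other. On the core of compound 3, methyl in place of hydrogen on a saturated chain carbon bound to two saturated chain carbons gives a number 16 percentage points higher from compound 3 to compound 4 (beyond the scatter) in this assay, and the two steps differ: the same change on two cores in this assay, a number 1 percentage points higher (within the scatter) from compound 1 to compound 2 and a number 16 percentage points higher (beyond the scatter) from compound 3 to compound 4, 15 percentage points apart, beyond the scatter of two such steps. This rests on one pair per core and does not show which difference between the cores goes with the larger step. Compound 4 at 18% is also a read-out at a single concentration, not a potency.

Open, from the compounds shown here alone, is how a longer chain or an amine at this place would read on either core. Also open, going by these compounds, is whether the larger step recurs on other cores.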